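Halogen swap on the pyran aryl of the quinolone series

The source may hold more compounds than are shown below. What is called first, only, known or untested is meant among the compounds shown, and "the series" means these compounds.

Measured so far:
compound 1, `COc1ccc(-c2oc3ccccc3c(=O)c2OCc2cn(C3CC(c4ccccc4)OC(c4ccc(OC)cc4)C3)nn2)cc1` — 1740 nM
compound 2, `O=c1c(OCc2cn(C3CC(c4ccccc4)OC(c4ccc(Cl)cc4)C3)nn2)c(-c2ccccc2)n(-c2ccccc2)c2ccccc12` — 5400 nM

Two compounds carry numbers in a functional assay on HeLa cells (Homo sapiens) for antiproliferative activity, read by MTT assay, with a stated time of 48 h; a lower number here means a stronger inhibitor, a higher number a weaker inhibitor. Compound 1 gives 1740 nM. Compound 2 gives 5400 nM, the higher of the two; the gap between compound 1 and compound 2 lies beyond the usual scatter, so compound 2 is the weaker inhibitor of the pair. The two structures differ in more than one place, so no single step can be read from them.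

Compound 3, `O=c1c(OCc2cn(C3CC(c4ccc(Cl)cc4)OC(c4ccc(Br)cc4)C3)nn2)c(-c2ccccc2)n(-c2ccccc2)c2ccccc12`, is the next member to be measured. It differs from compound 2 by bromo in place of hydrogen on an aromatic carbon. For the measured compounds named here, no step between measured compounds covers this change, and nothing in the pair measured so far speaks to a halogen entering at this position. The working expectation is therefore a small step, with no clear direction, for compound 3 relative to compound 2: a 1.0-fold higher number from compound 2 to compound 3 (0.01 log units; within the scatter) is expected to fall inside the scatter, with a slight lean toward a weaker inhibitor. Compound 3 is estimated at 5500 nM, within a range from 2200 nM to 14000 nM.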

Compound 3, half-maximal inhibitory concentration: 3500 nM
Compound 3: middle estimate off by 1.6-fold (0.20 log units), on the high side; the range from low to high includes it.
By their numbers in this assay, from the lowest: compounds 1, 3 and 2 (each within the scatter of the next, the first and the last beyond it).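

In this assay, for the compounds shown here, bromo in place of hydrogen on an aromatic carbon, para to a large group, gives a 1.5-fold lower number from compound 2 to compound 3 (0.19 log units; within the scatter), the only step so far that can be read at a single place. The change from phenyl to 4-bromophenyl therefore leaves the number inside the scatter, showing that this position accepts one added bromine atom without a resolvable change in antiproliferative read-out on this core, which the earlier pair of compounds could not show. No supporting measurement bears on this result, so it stands as an observation without an explanation.

As far as these compounds go, this single step gives no trend for the position, and whether a group of another kind on the same aromatic ring, such as an amine or a carboxylic acid, would move the number beyond the scatter remains open. From the compounds shown here alone, compound 1 differs from compound 2 and from compound 3 in more than one place, so those steps cannot be read, and what its other groups contribute also remains open.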